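The source may hold more compounds than are shown below. What is called first, only, known or untested is meant among the compounds shown, and "the series" means these compounds.

In a functional assay on C8166 cells (Homo sapiens) for cytotoxicity, read by MTT assay, with a stated time of 72 h (on this read-out lower numbers stand for higher toxicity in this test and higher numbers for lower toxicity in this test), compound 1 `Cc1ccc(S(=O)(=O)N2CC3(C[C@H]2C(=O)NN)SCCS3)cc1` reaches only a limit, > 519000 nM. Compound 3 `C/C(=N\NC(=O)Cn1c(=O)c(C)nc2ccccc21)c1ccc(Cl)cc1` also gives only a limit, > 543000 nM. Going by the values given here, compound 2 `Cc1ccc(S(=O)(=O)N2CC3(C[C@H]2C(=O)N/N=C/c2ccccc2F)SCCS3)cc1` holds the only actual number, 280000 nM. Compound 4 `Cc1ccc(S(=O)(=O)N2CC3(C[C@H]2C(=O)N/N=C/c2cccc([N+](=O)[O-])c2)SCCS3)cc1` differs from compound 2 by 3-nitrophenyl in place of 2-fluorophenyl on a carbon with a double bond to nitrogen. Among the compounds with values here, the one measured step, an at least 1.8-fold lower number from compound 1 to compound 2 (0.26 log units; that floor lies within the scatter), does not exchange these groups, and its floor lies within the scatter. The expectation therefore rests on compound 2 at 280000 nM, with no change beyond the scatter foreseen. The expected step is a 1.1-fold lower number from compound 2 to compound 4 (0.05 log units; within the scatter). Compound 4 is estimated at 250000 nM, with an expected range of 100000 nM to 450000 nM.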

Compound 4, half-maximal cytotoxic concentration: > 395000 nM
Compound 4: a limit, no number; the forecaster's own chance of this, stated with the estimate: 35%; at least 1.5-fold (0.19 log units) between middle value and limit.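

In this assay compound 4 gives only a limit, not a number: the limit of > 395000 nM in this assay, at which 1 of the 4 values shown sits. The exchange of 2-fluorophenyl for 3-nitrophenyl on this carbon is read as an at least 1.4-fold higher number from compound 2 to compound 4 (0.14 log units; that floor lies within the scatter), so this larger group brings no lower number at this position. The step from compound 1 to compound 4 cannot be read.

Going by these compounds, how far the true value of compound 4 lies past its limit stays open. So does what an aminophenyl or a carboxyphenyl group on this carbon would give in this assay.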